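This account rests on a few compounds, and the source may have more. Where it says the series, first, only, none or still open, it means among the compounds named here.

In a functional assay on SK-N-SH cells (Homo sapiens) for cytotoxicity, read by MTT assay, with a stated time of 48 h (on this read-out lower numbers stand for stronger inhibition and higher numbers for weaker inhibition), compound 1 `COc1cc(/C=C/c2ccccc2)c(-c2ccccc2)c(OC)c1OC` gives 63000 nM, while compound 2 `C=C(c1ccc(OC)cc1)c1cc(OC)c(OC)c(OC)c1-c1ccccc1` gives 31000 nM, the lower of the two numbers by a gap beyond the scatter. Compound 3 `C=C(c1ccc(C)cc1)c1cc(OC)c(OC)c(OC)c1-c1ccccc1` has not yet been measured. Relative to compound 2, it has methyl in place of methoxy on an aromatic carbon, para to a large group, turning 4-methoxyphenyl into 4-methylphenyl: methyl in place of methoxy on an aromatic carbon. Among the measured compounds shown here, no measured pair shows this change directly. The expected result is no shift beyond the scatter, with an estimated 1.1-fold higher number from compound 2 to compound 3 (0.05 log units; within the scatter). The estimated value for compound 3 is 35000 nM, within an expected range of 12000 nM to 90000 nM.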

Compound 3, half-maximal inhibitory concentration: 31000 nM
For compound 3 the middle estimate is 1.1-fold (0.05 log units) above the measured one; measured number inside the range.
By their numbers in this assay, from the lowest: compounds 2 and 3 (each within the scatter of the next); then compound 1.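

In this assay, 4-methylphenyl can stand in place of 4-methoxyphenyl with no change at the digits printed from compound 2 to compound 3 (within the scatter), so at this place the oxygen of the methoxy group is not needed to hold the number of compound 2. With 1-(4-methylphenyl)ethenyl in place of 2-phenylethenyl there is a 2.0-fold lower number from compound 1 to compound 3 (0.31 log units; beyond the scatter), so the gap seen earlier with compound 2 remains without any methoxy group at this place. Nothing available explains either step. As far as these compounds go, whether an amine, a carboxylic acid or a longer chain at this place would shift the number remains open.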